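Can a substituted ring lift compound 4 off the limit?

The source may report more compounds than this note shows. Statements on the series, on what has been measured and on what is new or still open speak of the compounds shown alone.

Values in an ADME assay on PA-1 cells (Homo sapiens) for cytotoxicity, read by MTT assay, with a stated time of 72 h (a lower number here means a stronger inhibitor, a higher number a weaker inhibitor), so far
- Compound 1 `COc1ccc(OC)c(C2=C(c3cc(OC)c(OC)c(OC)c3)C(=O)CC2O[SiH2]C(C)(C)C)c1` gives 17 ug/mL
- Compound 2 `COc1cc(C2=C(c3cc(C)c(OC)c(C)c3)C(O)CC2=O)cc(OC)c1OC` gives > 100 ug/mL (a limit)
- Compound 3 `COc1cc(C2=C(c3ccccc3)C(O[SiH2]C(C)(C)C)CC2=O)cc(OC)c1OC` gives > 100 ug/mL (a limit)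

Compound 3 gives > 100 ug/mL in this assay as a limit and not a number, and it stands at the limit of > 100 ug/mL in this assay, at which 2 of the 3 values shown sit, here. Compound 4 `COc1cc(C2=C(c3cc(C)c(OC)c(C)c3)C(O[SiH2]C(C)(C)C)CC2=O)cc(OC)c1OC` differs from compound 3 in one place, with 4-methoxy-3,5-dimethylphenyl in place of phenyl on a double-bonded ring carbon.

Within the data shown here, one measured step bears on this change, also at a double-bonded ring carbon. Phenyl in place of 2,5-dimethoxyphenyl gave an at least 5.8-fold higher number from compound 1 to compound 3 (0.76 log units; beyond the scatter), a step beyond the scatter. Read in reverse, it suggests that a substituted ring could bring the number down from the level of compound 3. Caution comes from compound 2, which carries the same 4-methoxy-3,5-dimethylphenyl and gives > 100 ug/mL, also a limit.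

A moderate move toward a lower number is therefore expected, and a result at the limit remains quite possible. The expected change is an at least 2.2-fold lower number from compound 3 to compound 4 (0.34 log units; beyond the scatter) in this assay. For compound 4 the estimate is 45 ug/mL, with an expected range from 14 ug/mL to 110 ug/mL.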

Compound 4, half-maximal inhibitory concentration: 32 ug/mL
Beside the measured number, compound 4's estimate is 1.4-fold (0.15 log units) above it; the measured number falls inside the stated range.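

In this assay, 4-methoxy-3,5-dimethylphenyl in place of phenyl gives an at least 3.1-fold lower number from compound 3 to compound 4 (0.49 log units; beyond the scatter), so 2,5-dimethoxyphenyl is not the only substituted ring that yields a measurable value at this position. Set against that ring, the new one gives a 1.9-fold higher number from compound 1 to compound 4 (0.27 log units; within the scatter), so the two cannot be told apart here. The ring alone does not account for the value: a group of 5 heavy atoms (4 carbon, 1 silicon; no ring) in place of a hydrogen atom, on an oxygen on a saturated carbon, gives an at least 3.1-fold lower number from compound 2 to compound 4 (0.49 log units; beyond the scatter).

As far as these compounds go, the full size of these last two kinds of step stays unknown, since compound 2 and compound 3 each give a limit and not a number: the limit of > 100 ug/mL in this assay, at which 2 of the 4 values shown sit. Also open is how a ring carrying an amine or a carboxylic acid would behave on this double-bonded ring carbon.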